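The source may report more compounds than this note shows. Statements on the series, on what has been measured and on what is new or still open speak of the compounds shown alone.

Working notes on the urea series. For the measured compounds named here, in an ADME assay on the whole organism with Oryza sativa as the target, tested at 10 uM (a higher number here means a weaker effect of the compound at the concentration tested, a lower number a stronger effect), compound 2 `CCc1cccc(NC(=O)N[C@@H](C)c2ccccc2)c1` gives 86% and stands highest of the three numbers so far. Compound 1 `CCc1cccc(NC(=O)N[C@H](C)c2ccccc2)c1` gives 36% in this assay, and compound 3 `C[C@@H](NC(=O)Nc1ccccc1C(F)(F)F)c1ccccc1` gives 54%. Going by the values given here, the only one-place step measured is a number 50 percentage points higher from compound 1 to compound 2 (beyond the scatter), a large change that rests on (the fact that compounds 1 and 2 differ only in the configuration as drawn). The next compound, compound 4 `C[C@H](NC(=O)Nc1cccc(C(F)(F)F)c1)c1ccccc1`, keeps the configuration of compound 2 and changes the ring substituent: trifluoromethyl in place of ethyl on an aromatic carbon. Among the compounds with values here, no measured step covers this exchange; the stereo step from compound 1 to compound 2 concerns a different part of the molecule, and compound 3 carries its trifluoromethyl at another place and with a different configuration, so its value of 54% gives no direct step to compound 4. For compound 4 a moderate downward step from compound 2 is expected, a number 16 percentage points lower from compound 2 to compound 4 (beyond the scatter), with wide uncertainty. The estimate for compound 4 in this assay is 70%, in the range 45% to 90%.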

Compound 4, a percentage reported as activity, at one concentration (the size of the read-out at that concentration, not a potency): 92%
For compound 4 the middle estimate is 22 percentage points below the measured one; the measured number lies above the stated range.
By their numbers in this assay, from the lowest: compound 1; then compound 3; then compounds 2 and 4 (each within the scatter of the next).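

In this assay, the exchange at this aromatic carbon, meta to a large group, gives a number 6 percentage points higher from compound 2 to compound 4 (within the scatter), so with this configuration the numbers do not separate ethyl from trifluoromethyl. Among the one-place steps now available, the only one beyond the scatter is still the change of configuration, a number 50 percentage points higher from compound 1 to compound 2 (beyond the scatter), although this comparison rests on just these two pairs. Nothing at hand gives a reason for the result of the ethyl to trifluoromethyl exchange.

From the compounds shown here alone, it remains open whether the same exchange would also stay within the scatter in the configuration of compound 1. The compounds shown also leave open what an amine or a carboxylic acid would give on this aromatic carbon, in place of ethyl or trifluoromethyl.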